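This account rests on a few compounds, and the source may have more. Where it says the series, first, only, none or still open, it means among the compounds named here.

For the measured compounds named here, in an assay on cells for inhibition of HSP60/HSP10 (Homo sapiens), with a stated time of 60 min (a lower number here means a stronger inhibitor, a higher number a weaker inhibitor), three compounds have values so far.

Compound 1 `O=S(=O)(Nc1ccc2oc(-c3ccccc3)nc2c1)c1ccccc1F` gives > 100000 nM, which is a limit of the assay.
Compound 2 `O=S(=O)(Nc1ccc2oc(-c3ccccc3)nc2c1)c1ccc(Cl)c(C(F)(F)F)c1` gives > 100000 nM, again a limit of the assay.
Compound 3 `O=S(=O)(Nc1ccc(-c2nc3cc(NS(=O)(=O)c4ccccc4F)ccc3o2)cc1)c1ccccc1F` gives 57000 nM.

Compound 1 therefore has no number of its own in this assay, only a limit, and it shares that position with another compound, since (the limit of > 100000 nM in this assay, at which 2 of the 3 values shown sit). Going by the values given here, the single measured step that starts from compound 1 is an at least 1.7-fold lower number from compound 1 to compound 3 (0.24 log units; that floor lies within the scatter); that step adds a second sulfonamide group to the shared core and leaves the sulfonyl aryl group untouched. Compound 4 `COc1ccc(Cl)cc1S(=O)(=O)Nc1ccc2oc(-c3ccccc3)nc2c1` differs from compound 1 by 5-chloro-2-methoxyphenyl in place of 2-fluorophenyl on a sulfonyl sulfur. Compound 2, which carries another substituted phenyl on the same sulfonyl sulfur, also reaches only a limit. Among the compounds with values here, no measured step directly probes an exchange of the aryl group on the sulfonyl sulfur, so no step beyond the usual scatter is expected here. The estimate for compound 4 in this assay is 100000 nM, with a range from 40000 nM to 300000 nM. The step this estimate means is expected to be a number no higher from compound 1 to compound 4 (the limit leaves the size open).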

Compound 4, half-maximal inhibitory concentration: > 100000 nM
Compound 4 was reported as a limit; the forecaster's own chance of this, stated with the estimate: 70%; the middle value lies on the limit itself.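

In this assay compound 4 gives > 100000 nM as a limit of the assay. For the compounds shown here, compound 1 also has only a limit, so no step between compound 1 and compound 4 can be read: the limit of > 100000 nM in this assay, at which 3 of the 4 values shown sit.

From the compounds shown here alone, whether 5-chloro-2-methoxyphenyl or 2-fluorophenyl on the sulfonyl sulfur gives the lower number stays open.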